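The source may report more compounds than this note shows. Statements on the series, on what has been measured and on what is new or still open speak of the compounds shown alone.

Measured compounds:
- compound 1, `CCCN(CCC)Cc1ccc(Cl)c(-c2ccccc2OC)c1`: "not active" (no number reported)
- compound 2, `CNCc1ccc(Cl)c(-c2ccccc2OC)c1`: 61%
- compound 3, `CCNCc1ccc(Cl)c(-c2ccccc2OC)c1`: "not active" (no number reported)

All three share one core and differ only in the amine at the chain end. In a functional assay on HEK293 cells for agonist activity at 5-hydroxytryptamine receptor 7 (Homo sapiens), read by a luciferase reporter and beta-arrestin recruitment, with a stated time of 22 h (on this read-out higher numbers stand for larger maximal responses and lower numbers for smaller maximal responses), compound 2 gives 61%. Compound 1 is reported in this assay as "not active" (no number reported), and compound 3 likewise as "not active" (no number reported), so neither of these two carries a number, and compound 3 stands among the entries without a single value; only compound 2 offers a measured response.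

Compound 4, `COc1ccccc1-c1cc(CN(C)C)ccc1Cl`, has not been measured in this assay. It differs from compound 3 as follows: dimethylamino in place of ethylamino on a saturated chain carbon bound to an aromatic carbon. Going by the values given here, no measured step covers this change, and the three measured compounds do not suggest a direction on their own; the change from compound 3 to compound 4 is expected to move the response upward, from no reported activity toward a measurable maximal response, though the size is uncertain. For compound 4 in this assay the expected value is 35%, with a range from 5% to 70%.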

Compound 4, largest response reached (Emax), in percent of the reference or control that the assay uses: 43%
The estimate for compound 4 lay 8 percentage points below the measured number, within the range that was stated.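

In this assay compound 4, which carries dimethylamino and so has no hydrogen-bond donor in that group, gives 43% and is the first compound shown with a response and no hydrogen on the amine nitrogen. Methyl in place of hydrogen on that nitrogen gives a number 18 percentage points lower from compound 2 to compound 4 (beyond the scatter) and lowers the response without abolishing it. Compound 3 has the same atoms joined differently, with ethylamino in place of dimethylamino, and is reported as "not active" (no number reported) in this same assay, so at this position the arrangement of the two carbons on the nitrogen separates a reported response from none.

Going by these compounds, whether isopropylamino or pyrrolidine in place of dimethylamino would keep a response remains open. No measurement given here explains why these amines differ.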